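The source may hold more compounds than are shown below. What is called first, only, known or untested is meant among the compounds shown, and "the series" means these compounds.

Compound 1 `O=c1nc(NCc2ccc(F)cc2)oc2c([N+](=O)[O-])cc(C(F)(F)F)cc12`: > 64 ug/mL
Compound 2 `O=c1nc(NCC2CCCCC2)oc2c([N+](=O)[O-])cc(C(F)(F)F)cc12`: 29.7 ug/mL

In an ADME assay on Vero cells (Chlorocebus sabaeus) for cytotoxicity, read by MTT assay, with a stated time of 48 h (a higher number here means a weaker inhibitor, a lower number a stronger inhibitor), compound 1 gives only a limit, > 64 ug/mL. Compound 2 gives 29.7 ug/mL in this assay, the only number shown among the two measured compounds. Compound 3 `O=c1nc(Nc2ccccc2)oc2c([N+](=O)[O-])cc(C(F)(F)F)cc12` is not yet measured; it differs from compound 2 by phenyl in place of cyclohexylmethyl on a nitrogen on an aromatic ring. For the measured compounds named here, one measured step bears on this: an at least 2.1-fold lower number from compound 1 to compound 2 (0.33 log units; beyond the scatter), where cyclohexyl in place of 4-fluorophenyl lowered the number. Putting an aromatic ring back in compound 3 is expected to raise the number again, so the estimated step is a 1.7-fold higher number from compound 2 to compound 3 (0.23 log units; within the scatter). Compound 3 is therefore expected to give about 50 ug/mL, between 25 ug/mL and 100 ug/mL.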

Compound 3, half-maximal inhibitory concentration: 37.9 ug/mL
Compound 3: middle estimate off by 1.3-fold (0.12 log units), on the high side, and the stated range covers the measured number.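

Phenyl and cyclohexylmethyl on this nitrogen cannot be told apart in this assay: a 1.3-fold higher number from compound 2 to compound 3 (0.11 log units; within the scatter). Compound 1 gives only a limit, not a number: the limit of > 64 ug/mL in this assay, at which 1 of the 3 values shown sits. Phenyl in place of 4-fluorobenzyl gives an at least 1.6-fold lower number from compound 1 to compound 3 (0.22 log units; that floor lies within the scatter), so this pair is not clearly separated either.

On these data alone, what an amine, a carboxylic acid or a longer open alkyl chain on this nitrogen would give remains open. It is also unclear whether the number depends more on the ring or on the chain carbon linking it to the nitrogen.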